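Will Compound 4 Outlast Compound 3?

The compounds below may be only part of what the source reports. "The series", "measured", "known", "first", "only" and "open" are said of these compounds alone.

In an ADME assay (liver) for metabolic stability, with Liver microsome (Homo sapiens) as the target, using microsomes (on this read-out higher numbers stand for a longer-lived compound and lower numbers for a shorter-lived compound), compound 1 `CCc1nc2ccc(Cl)cn2c1C(=O)NCc1ccc(-c2ccc(C#N)cc2)cc1` gives > 2 h, which is a limit of the assay. Compound 2 `CCc1nc2cc(Cl)ccn2c1C(=O)NCc1ccc(-c2ccc(Cl)cc2)cc1` gives > 2 h, also a limit. Within the data shown here, compound 3 `CCc1nc2cc(Cl)ccn2c1C(=O)NCc1ccc(-c2ccncc2)cc1` gives 0.482 h, the only actual number in this small set.

Compound 4 `CCc1nc2cc(Cl)ccn2c1C(=O)NCc1ccc(N2CCC(Cl)CC2)cc1` differs from compound 3 by one change: 4-chloropiperidin-1-yl in place of pyridin-4-yl on an aromatic carbon. Among the measured compounds shown here, one measured step bears on this change, since it also alters the group at that place: swapping 4-chlorophenyl for pyridin-4-yl gave an at least 4.1-fold lower number from compound 2 to compound 3 (0.61 log units; beyond the scatter). That step shows that the half-life in this assay can respond to this group, and pyridin-4-yl sits on the lower side of it. However, the incoming ring is non-aromatic, and no measured compound carries such a ring, so this is only a rough guide. A modest rise is therefore expected, smaller than that measured step suggests. The estimated change is a 2.1-fold higher number from compound 3 to compound 4 (0.32 log units; beyond the scatter). The expected value for compound 4 is 1 h, with an estimated range from 0.4 h to 2 h.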

Compound 4, half-life: 0.183 h
Compound 4: the middle estimate sits 5.5-fold (0.74 log units) above what was measured; measured number below the stated range.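

In this assay, among these compounds, compound 4 puts a non-aromatic ring, 4-chloropiperidin-1-yl, on the aromatic carbon for the first time in this set, and the result is a 2.6-fold lower number from compound 3 to compound 4 (0.42 log units; beyond the scatter). Pyridin-4-yl is therefore not the low end for this position, and moving away from it does not by itself lengthen the half-life. Against 4-chlorophenyl, the same swap gives an at least 10-fold lower number from compound 2 to compound 4 (1.03 log units; beyond the scatter), and this size is only a floor because compound 2 gives no actual number: the limit of > 2 h in this assay, at which 2 of the 4 values shown sit.

The compounds shown leave open whether the shorter half-life goes with the non-aromatic ring itself or with its chlorine, a question that a plain piperidin-1-yl at this place would help to settle. From the compounds shown here alone, how a morpholin-4-yl ring would fare here also remains open.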